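Notes on the step to compound 4

The source may hold more compounds than are shown below. What is called first, only, known or untested is meant among the compounds shown, and "the series" means these compounds.

compound 1 `COc1ccc2c(=O)c(/C=C/C(=O)NCc3ccccc3)coc2c1`: > 100000 nM, a limit
compound 2 `COc1ccc2c(=O)c(/C=C/C(=O)Nc3cc(C)ccc3C)coc2c1`: > 100000 nM, a limit
compound 3 `COc1cccc(NC(=O)/C=C/c2coc3cc(OC)ccc3c2=O)c1`: 39100 nM

All three were tested in a functional assay (QGY7701 cells, Homo sapiens) for inhibition, read by MTT assay, with a stated time of 48 h; a higher number here means a weaker inhibitor, a lower number a stronger inhibitor. Compound 3 alone gives a number. The other two sit at the limit of > 100000 nM in this assay, at which 2 of the 3 values shown sit.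

Compound 4 `COc1ccc2c(=O)c(/C=C/C(=O)NCc3cccc(F)c3)coc2c1` carries 3-fluorobenzyl in place of 3-methoxyphenyl on an amide-type nitrogen. The nearest measured step is an at least 2.5-fold lower number from compound 1 to compound 3 (0.40 log units; beyond the scatter), where 3-methoxyphenyl replaced benzyl. The step of an at least 2.5-fold lower number from compound 2 to compound 3 (0.40 log units; beyond the scatter) points the same way. Compound 4 returns to a benzyl-type group, so the change seen in an at least 2.5-fold lower number from compound 1 to compound 3 (0.40 log units; beyond the scatter) is expected to reverse, towards a higher number, and a limit may well be reported. The expected step is a 2.2-fold higher number from compound 3 to compound 4 (0.34 log units; beyond the scatter). For compound 4 the estimated value is 85000 nM, with an expected range of 35000 nM to 160000 nM.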

Compound 4, half-maximal inhibitory concentration: 28600 nM
For compound 4 the middle estimate is 3.0-fold (0.47 log units) above the measured one, and the stated range ends above it.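

In this assay a benzyl-type group on the amide-type nitrogen gives a measurable value once fluoro stands in place of hydrogen on an aromatic carbon, with an at least 3.4-fold lower number from compound 1 to compound 4 (0.54 log units; beyond the scatter) in this one pair. 3-Fluorobenzyl and 3-methoxyphenyl cannot be told apart, with a 1.4-fold lower number from compound 3 to compound 4 (0.14 log units; within the scatter) while 3-fluorobenzyl in place of 2,5-dimethylphenyl gives an at least 3.4-fold lower number from compound 2 to compound 4 (0.54 log units; beyond the scatter) at the same nitrogen. Compound 1 and compound 2 each give a limit, and the two steps from them are bounds only: the limit of > 100000 nM in this assay, at which 2 of the 4 values shown sit.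

Open, from the compounds shown here alone, is whether an amine or a carboxylic acid on the benzyl ring, or a longer chain on the amide-type nitrogen, keeps this level of inhibition.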